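Replacing the 2-chloro-4-methylphenyl group: working notes

This account rests on a few compounds, and the source may have more. Where it says the series, first, only, none or still open, it means among the compounds named here.

Of the compounds shown here, three have numbers so far in a physicochemical assay for lipophilicity, read by HPLC, in phosphate buffer, measured as octanol-water partition, at pH 7.4, tested at 100 uM; a lower number here means a more polar compound, a higher number a more lipophilic compound. Compound 1 `O=C(O)COc1ccc(NCc2cccc(-c3ccccc3F)c2)cc1F` gives 2.36, compound 2 `O=C(O)COc1ccc(NCc2cccc(-c3ccccc3Cl)c2)cc1F` gives 2.71, and compound 3 `Cc1ccc(-c2cccc(CNc3ccc(OCC(=O)O)c(F)c3)c2)c(Cl)c1` gives 3.24. That last number is the highest of the three, and its gaps to both others lie beyond the scatter.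

The next compound is compound 4 `CCOc1ccc(-c2cccc(CNc3ccc(OCC(=O)O)c(F)c3)c2)c(C)c1`, which carries this change: 4-ethoxy-2-methylphenyl in place of 2-chloro-4-methylphenyl on an aromatic carbon. Among the measured compounds shown here, three measured steps bear on it, all upward and all modest. Chloro in place of fluoro gave a number 0.35 log units higher from compound 1 to compound 2 (beyond the scatter). Methyl in place of hydrogen gave a number 0.53 log units higher from compound 2 to compound 3 (beyond the scatter). The exchange of 2-fluorophenyl for 2-chloro-4-methylphenyl gave a number 0.88 log units higher from compound 1 to compound 3 (beyond the scatter).

None of these steps matches the present change. For the measured compounds named here, no measured compound carries ethoxy, and none shows chloro exchanged directly for methyl. The chloro step and the methyl step are similar in size, and here chloro leaves while ethoxy enters, so the two parts of the change may largely offset each other. As far as these compounds go, no step beyond the scatter is therefore expected in this assay, and the direction stays open. The estimated step is a number 0.06 log units higher from compound 3 to compound 4 (within the scatter). For compound 4 the expected value is 3.3, with an estimated range of 2.9 to 3.7.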

Compound 4, distribution coefficient: 2.83
Compound 4: the middle estimate sits 0.47 log units above what was measured; the measured number lies below the stated range.
By their numbers in this assay, from the lowest: compound 1; then compounds 2 and 4 (each within the scatter of the next); then compound 3.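

In this assay, among the compounds shown here, 4-ethoxy-2-methylphenyl in place of 2-chloro-4-methylphenyl gives a number 0.41 log units lower from compound 3 to compound 4 (beyond the scatter), the first downward step, so at this aromatic carbon, meta to a large group, a group of 10 heavy atoms with 1 hydrogen-bond acceptor does not read above one of 8 heavy atoms with none. Measured against the simpler groups, the same 4-ethoxy-2-methylphenyl group gives a number 0.12 log units higher from compound 2 to compound 4 (within the scatter) and a number 0.47 log units higher from compound 1 to compound 4 (beyond the scatter), which places compound 4 level with compound 2 and clear of compound 1 only, so the upward run through compounds 1, 2 and 3 does not extend to compound 4. Nothing shown here accounts for the drop.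

As far as these compounds go, the step to compound 4 joins two exchanges, methyl for chloro and ethoxy for methyl, and how much of it belongs to each stays open. A 2-chloro-4-ethoxyphenyl group would part the two, and a longer chain such as propoxy or an amine in the place of the ethoxy would show whether the step follows the group that enters.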